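The source may report more compounds than this note shows. Statements on the series, on what has been measured and on what is new or still open speak of the compounds shown alone.

Compound 1 `Cc1nnc(-c2nc(C)c3c(c2N)C(=O)N(Cc2ccccc2)C3=O)o1` gives < 5000 nM in a physicochemical assay for solubility, using the shake flask method, in simulated intestinal fluid, measured as kinetic solubility, with a stated time of 2 h, at 25 degrees C, at pH 6.5 (on this read-out lower numbers stand for lower solubility and higher numbers for higher solubility), which is a limit of the measurement.
Compound 2 `Cc1noc(-c2nc(C)c3c(c2N)C(=O)N(Cc2ccc(F)cc2)C3=O)n1` gives < 5000 nM in this assay, again a limit.
Compound 3 `Cc1noc(-c2nc(C)c3c(c2N)C(=O)N(Cc2ccc(-c4ccncc4)cc2)C3=O)n1` gives < 5000 nM in this assay, also a limit.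

Compound 2 thus stands only at a limit, and no number is known for it; (the limit of < 5000 nM in this assay, at which 3 of the 3 values shown sit). Compound 4 `Cc1noc(-c2nc(C)c3c(c2N)C(=O)N(Cc2ccccc2C(F)(F)F)C3=O)n1` differs from compound 2 by 2-(trifluoromethyl)phenyl in place of 4-fluorophenyl on a saturated chain carbon bound to an amide-type nitrogen in a ring. Among the measured compounds shown here, the single measured step, a step that the two limits leave unreadable from compound 2 to compound 3, runs between two limits and so carries no readable size. Nothing measured therefore speaks for or against a change beyond the scatter for compound 4, and the expectation is simply that it remains near the same limit. Compound 4 is estimated at 2000 nM, with a range from 400 nM to 6000 nM. The expected step is a step that the limit leaves unreadable from compound 2 to compound 4.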

Compound 4, solubility: < 5000 nM
Compound 4 gave a limit, no number (the forecaster's own chance of this, stated with the estimate: 80%); the middle value lies beyond the limit too.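

In this assay compound 2 and compound 4 both give only a limit, and the step between them cannot be read. The compounds shown leave open what the actual solubility of each one is and whether 2-(trifluoromethyl)phenyl in place of 4-fluorophenyl changes it.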